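The source may hold more compounds than are shown below. What is called first, only, known or untested is meant among the compounds shown, and "the series" means these compounds.

Measured so far in an ADME assay on microsomes from liver (Rattus norvegicus) for metabolic stability, read by LC-MS, with a stated time of 30 min, tested at 0.5 uM; a higher number here means that more of the compound is left, a lower number that less of the compound is left:
- compound 1 `c1ccc(-c2nc(-c3csc(N=C4NCCCN4)n3)cs2)cc1`: 31%
- compound 2 `Oc1ccccc1-c1nc(-c2csc(N=C3NCCCN3)n2)cs1`: 38%
- compound 3 `c1cncc(-c2nc(-c3csc(N=C4NCCCN4)n3)cs2)c1`: 19%

Compound 1 stands clearly above compound 3 only, and it cannot be told apart from compound 2. Compound 4 `CS(=O)(=O)c1ccc(-c2nc(-c3csc(N=C4NCCCN4)n3)cs2)cc1` has not yet been measured. It keeps the core of compound 1 and differs in one place: methylsulfonyl in place of hydrogen on an aromatic carbon. Methylsulfonyl replaces hydrogen on an aromatic carbon of a six-membered aromatic ring of carbon only, para to a large group.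

Within the data shown here, two measured steps bear on this change. The closest in kind also puts a group in place of hydrogen on an aromatic carbon, and it gave a number 7 percentage points higher from compound 1 to compound 2 (within the scatter). Replacing phenyl with pyridin-3-yl gave a number 12 percentage points lower from compound 1 to compound 3 (beyond the scatter). Neither step involves methylsulfonyl, and they point in opposite directions, so no clear direction can be drawn from them. The expected step is a number 1 percentage points higher from compound 1 to compound 4 (within the scatter), so no change beyond the scatter is foreseen. For compound 4 the estimate is 32%, with an expected range of 15% to 52%.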

Compound 4, percent of the compound remaining: 53%
Estimate against measurement, compound 4: 21 percentage points below; measured number outside the range, above it.
By their numbers in this assay, from the lowest: compound 3; then compounds 1 and 2 (each within the scatter of the next); then compound 4.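

On the six-membered aromatic ring of carbon only, methylsulfonyl in place of hydrogen, para to a large group, gives a number 22 percentage points higher from compound 1 to compound 4 (beyond the scatter) in this assay. Among these compounds, the earlier hydroxy change on an aromatic carbon gave a number 7 percentage points higher from compound 1 to compound 2 (within the scatter), so this is the first group added to that ring to move the number upward beyond the scatter. No measured information here explains this rise.

The compounds shown leave open whether an amine, a carboxylic acid or a sulfonamide at the same place would also raise the number, so the rise cannot yet be tied to methylsulfonyl in particular. They also leave open whether methylsulfonyl would give a similar step on another aromatic carbon of that ring or on the pyridin-3-yl ring of compound 3.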